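Propoxy for pyrrolidinyl: a step toward compound 3

The compounds below may be only part of what the source reports. "The series", "measured", "known", "first", "only" and "open" are said of these compounds alone.

Measured so far:
Compound 1 `CC(C)CCOc1nc(C(C)(C)C)ccc1CNC(=O)C(C)c1ccc(NS(C)(=O)=O)c(F)c1`: 0.8 nM
Compound 2 `CC(C(=O)NCc1ccc(C(C)(C)C)cc1N1CCCC1)c1ccc(NS(C)(=O)=O)c(F)c1`: 8.1 nM

In an assay on cells for antagonist activity at transient receptor potential cation channel subfamily V member 1 (Homo sapiens), read by FLIPR and calcium flux, with a stated time of 6 min (on this read-out higher numbers stand for weaker inhibition and lower numbers for stronger inhibition), compound 2 gives 8.1 nM, the higher of the two numbers; compound 1 gives 0.8 nM, and that gap lies beyond the scatter. Compound 3 `CCCOc1cc(C(C)(C)C)ccc1CNC(=O)C(C)c1ccc(NS(C)(=O)=O)c(F)c1` differs from compound 2 by propoxy in place of pyrrolidin-1-yl on an aromatic carbon. Among the measured compounds shown here, no measured pair shows this exact change, so the expected step rests on the stronger showing of the alkoxy-bearing compound 1 at 0.8 nM. Compound 3 is expected to give a moderately lower number, a 2.7-fold lower number from compound 2 to compound 3 (0.43 log units; beyond the scatter), in this assay. The estimate for compound 3 is 3 nM, within 0.8 nM to 12 nM.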

Compound 3, inhibition constant: 4.4 nM
Beside the measured number, compound 3's estimate is 1.5-fold (0.17 log units) below it; low and high end bracket the measured number.
By their numbers in this assay, from the lowest: compound 1; then compounds 3 and 2 (each within the scatter of the next).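

In this assay, exchanging pyrrolidin-1-yl for propoxy on this aromatic carbon, ortho to a large group and meta to a tert-butyl group, gives a 1.8-fold lower number from compound 2 to compound 3 (0.27 log units; within the scatter) on the shared core. The ring with its nitrogen and the open chain with its oxygen therefore cannot be told apart here, so this position accepts both groups in this assay. Nothing available gives a reason for this.

The compounds shown leave open how a longer chain such as butoxy would read at this position. They also leave open how a small amine such as dimethylamino or a larger ring such as piperidin-1-yl would read there.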